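Imidazoline to Imidazole Swap on Two Aryl Cores

The source may report more compounds than this note shows. Statements on the series, on what has been measured and on what is new or still open speak of the compounds shown alone.

Compound 1 `c1ccc(-c2ccno2)c(OCC2=NCCN2)c1` gives 100 nM in a functional assay for activation of Alpha-1B adrenergic receptor (Homo sapiens); a lower number here means that less compound is needed, a higher number that more compound is needed for the effect. Compound 2 `c1ccc(-c2ccno2)c(OCc2c[nH]cn2)c1` gives only a limit in this assay, < 100000 nM. The change between them is a group of 5 heavy atoms (3 carbon, 2 nitrogen; one five-membered aromatic ring with 2 hetero atoms) in place of a group of 5 heavy atoms (3 carbon, 2 nitrogen; one five-membered non-aromatic ring with 2 hetero atoms), on a saturated chain carbon bound to an oxygen on an aromatic ring, and the size of the step, a step that the limit leaves unreadable from compound 1 to compound 2, cannot be read because the limit of < 100000 nM in this assay, at which 1 of the 3 values shown sits, sits in the way. Compound 3 `c1ccc(N2CCCCC2)c(NCC2=NCCN2)c1` also gives only a limit in this assay, < 5020 nM. The difference between the core of compound 3 and that of compound 1 is not broken down here. Compound 4 `c1ccc(N2CCCCC2)c(NCc2c[nH]cn2)c1` carries the same kind of change, (a group of 5 heavy atoms (3 carbon, 2 nitrogen; one five-membered aromatic ring with 2 hetero atoms) in place of a group of 5 heavy atoms (3 carbon, 2 nitrogen; one five-membered non-aromatic ring with 2 hetero atoms), on a saturated chain carbon bound to a nitrogen on an aromatic ring), here on a saturated chain carbon bound to a nitrogen on an aromatic ring rather than to an oxygen. The step of an at least 3.9-fold higher number from compound 3 to compound 4 (0.60 log units; beyond the scatter) is an expectation only, since it starts from a limit and the measured counterpart is unreadable. Compound 4 is expected to show 20000 nM, between 2000 nM and 100000 nM.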

Compound 4, half-maximal effective concentration: < 5020 nM
Compound 4 ended at the assay's limit; the forecaster's own chance of this, stated with the estimate: 60%; middle value at least 3.9-fold (0.60 log units) away from the limit.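

The step from compound 3 to compound 4 cannot be read, since both compounds give only limits in this assay: the limit of < 5020 nM in this assay, at which 2 of the 4 values shown sit. The compounds shown leave open how far the 1H-imidazol-4-yl group shifts the number on either core.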